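This account rests on a few compounds, and the source may have more. Where it says the series, first, only, none or still open, it means among the compounds named here.

Compound 1 `CCCCNc1nc(-c2ccccc2)c(Cc2c(O)ccc3ccccc23)c(=O)[nH]1` and compound 2 `CCN(CC)c1nc(-c2ccccc2)c(Cc2c(O)ccc3ccccc23)c(=O)[nH]1` share one core and differ only in the amine on an aromatic carbon. In a functional assay on EJ cells (Homo sapiens) for antiproliferative activity, read by MTT assay, with a stated time of 24 h (a higher number here means a weaker inhibitor, a lower number a stronger inhibitor), compound 1 gives 28700 nM, while compound 2 gives 79700 nM, the highest of the two numbers; the step of a 2.8-fold higher number from compound 1 to compound 2 (0.44 log units; beyond the scatter) swapped butylamino for diethylamino. Compound 3 `C#CCNc1nc(-c2ccccc2)c(Cc2c(O)ccc3ccccc23)c(=O)[nH]1` takes the change (propargylamino in place of diethylamino on an aromatic carbon), which again puts a hydrogen-bond donor on that nitrogen. Going by the values given here, since the only known step points that way, the number for compound 3 in this assay is expected to fall by about a 2.7-fold lower number from compound 2 to compound 3 (0.42 log units; beyond the scatter), estimated at 30000 nM with a range from 10000 nM to 80000 nM.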

Compound 3, half-maximal inhibitory concentration: 148000 nM
Compound 3: middle estimate off by 4.9-fold (0.69 log units), on the low side; measured number outside the range, above it.
By their numbers in this assay, from the lowest: compound 1; then compounds 2 and 3 (each within the scatter of the next).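

Having a hydrogen-bond donor on that nitrogen is not enough to match compound 1: in this assay the swap gives a 1.9-fold higher number from compound 2 to compound 3 (0.27 log units; within the scatter), so propargylamino and diethylamino cannot be told apart here. With a donor present in both compounds, the chain end still counts, as ethynyl in place of propyl gives a 5.2-fold higher number from compound 1 to compound 3 (0.71 log units; beyond the scatter). Nothing measured here accounts for this.

As far as these compounds go, it remains open whether the triple bond or the chain length separates compound 3 from compound 1; a propylamino group would distinguish the two. From the compounds shown here alone, how a ring amine such as morpholine behaves at this position is also open.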